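A few compounds are considered here, and "the series" means these few. Any claim that something is new, unique, unknown or untested is made for them only; others in the source may bear on it.

Measured compounds:
compound 1, `N=S1(=O)CC(Nc2nonc2/C(=N/O)Nc2ccc(F)c(Br)c2)C1`, 53 nM in an assay on HeLa cells for inhibition of Indoleamine 2,3-dioxygenase 1 (Homo sapiens), read by spectrophotometry, with a stated time of 24 h; on this read-out higher numbers stand for an effect only at larger amounts of compound and lower numbers for an effect already at smaller amounts
compound 2, `NS(=O)(=O)CCNc1nonc1/C(=N/O)Nc1ccc(F)c(Br)c1`, 11 nM in this assay
compound 3, `C#CCNS(=O)(=O)CCNc1nonc1/C(=N/O)Nc1ccc(F)c(Br)c1`, 33 nM in this assay

Compound 3 holds the second highest of the three numbers in this assay: it lies within the scatter of compound 1, and its step of a 3.0-fold higher number from compound 2 to compound 3 (0.48 log units; beyond the scatter) is the one gap beyond the scatter. Compound 4 `CN(C)S(=O)(=O)CCCNc1nonc1/C(=N/O)Nc1ccc(F)c(Br)c1` differs from compound 3 by (dimethylsulfamoyl)methyl in place of propargylsulfamoyl on a saturated chain carbon, two bonds along the chain from a nitrogen on an aromatic ring; read one bond further out, the same difference is 2-(propargylsulfamoyl)ethyl to 3-(dimethylsulfamoyl)propyl. For the measured compounds named here, two measured steps bear on it. The step of a 3.0-fold higher number from compound 2 to compound 3 (0.48 log units; beyond the scatter) shows that a propargyl on the sulfonamide nitrogen raised the number, and compound 4 removes that propargyl again, which by itself points to a lower number. The step of a 4.8-fold lower number from compound 1 to compound 2 (0.68 log units; beyond the scatter) shows that an open sulfonamide chain in place of the ring lowered the number, and compound 4 keeps an open chain. Going by the values given here, no measured step covers two methyls on that nitrogen or the longer chain, so the outcome is uncertain in both directions. The step of a 1.1-fold lower number from compound 3 to compound 4 (0.04 log units; within the scatter) is therefore expected to be small. Compound 4 is estimated at 30 nM, with a range from 10 nM to 90 nM.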

Compound 4, half-maximal effective concentration: 20 nM
For compound 4 the middle estimate is 1.5-fold (0.18 log units) above the measured one, and the stated range covers the measured number.
By their numbers in this assay, from the lowest: compounds 2, 4, 3 and 1 (each within the scatter of the next, the first and the last beyond it).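

In this assay, the entering (dimethylsulfamoyl)methyl has no hydrogen-bond donor and no triple bond, yet it gives a 1.7-fold lower number from compound 3 to compound 4 (0.22 log units; within the scatter) and, against the plain sulfamoyl, a 1.8-fold higher number from compound 2 to compound 4 (0.26 log units; within the scatter), both within the scatter. Among these open-chain compounds, then, a sulfonamide nitrogen carrying two methyls on a longer chain reads the same as one carrying propargyl or only hydrogens, while the ring of compound 1 stays apart, with a 2.7-fold lower number from compound 1 to compound 4 (0.42 log units; beyond the scatter). No measurement here explains why these groups read alike or why the ring differs.

From the compounds shown here alone, the two methyls and the longer chain enter together in compound 4, so their separate contributions remain unknown. Also open, going by these compounds, is how a single methyl on that nitrogen, or a carboxylic acid or an amine at the chain end, would read.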